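The source may hold more compounds than are shown below. What is called first, only, known or untested is meant among the compounds shown, and "the series" means these compounds.

Measured so far in an in vitro ADME assay on microsomes from liver (Rattus norvegicus) for metabolic stability; a lower number here means that the compound disappears faster, a higher number that the compound lasts longer:

- compound 1 `Cc1ccc2c(NCc3ccc(NC(=O)c4ccc(F)cc4)cc3)nc(N3CCN[C@H](C)C3)nc2c1`: 0.0667 h
- compound 2 `CC(O)c1ccc2c(NCc3ccc(NC(=O)c4ccc(F)cc4)cc3)nc(N(C)C)nc2c1`: 0.1 h

Among the compounds with values here, these are the only two numbers available. Compound 2 gives 0.1 h, and compound 1 gives 0.0667 h. The two values lie within the usual scatter of repeated measurements, so this assay does not separate these compounds.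

The next compound to be tested is compound 3 `CN(C)c1nc(NCc2ccc(NC(=O)c3ccc(F)cc3)cc2)c2ccc(CO)cc2n1`. It differs from compound 2 in one place: hydrogen in place of methyl on a saturated chain carbon bound to an aromatic carbon and an oxygen on a saturated carbon. This puts hydrogen in place of methyl on a saturated chain carbon bound to an aromatic carbon and an oxygen on a saturated carbon, turning 1-hydroxyethyl into hydroxymethyl.

Within the data shown here, no measured pair shows this change, so the data give no direct guide to its size or direction. The best starting point is therefore compound 2 itself, at 0.1 h, and no change beyond the scatter is expected. The expected step is no change at the digits printed from compound 2 to compound 3 (within the scatter). For compound 3, the estimated half-life is 0.1 h, with an expected range from 0.05 h to 0.2 h.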

Compound 3, half-life: 0.367 h
For compound 3 the middle estimate is 3.7-fold (0.56 log units) below the measured one; the whole stated range lies below it.
By their numbers in this assay, from the lowest: compounds 1 and 2 (each within the scatter of the next); then compound 3.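

In this assay, within the data shown here, this is the first change at this position that can be read on its own: going from 1-hydroxyethyl to hydroxymethyl gives a 3.7-fold higher number from compound 2 to compound 3 (0.56 log units; beyond the scatter). Compound 1 and compound 2 differ in more than one place, so they could not show that losing a single methyl, on a saturated chain carbon bound to an aromatic carbon and an oxygen, can move the half-life beyond the scatter with the rest of the molecule unchanged. No measurement shown explains why the number moves.

This single pair leaves open whether other groups at this place, such as methoxymethyl, aminomethyl or a carboxylic acid, would give a longer or shorter half-life than hydroxymethyl. It also leaves open whether the same swap from 1-hydroxyethyl to hydroxymethyl would give a step of similar size and direction in compounds that carry a different amine in place of the dimethylamino group.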